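Chloro to Bromo on a Shared Purine-Free Core Position

This account rests on a few compounds, and the source may have more. Where it says the series, first, only, none or still open, it means among the compounds named here.

Of the compounds shown here, two have been measured in a functional assay on A-375 cells (Homo sapiens) for antiproliferative activity, read by colorimetric assay and sulforhodamine B assay, with a stated time of 3 days (a higher number here means a weaker inhibitor, a lower number a stronger inhibitor), so far. Compound 1 `CCOC(=O)Cn1cnc2c(Cl)ncnc21` gives 18900 nM in this assay, which is the higher of the two numbers. Compound 2 `CCOC(=O)Cn1cnc2ncnc(Cl)c21` gives 14500 nM in this assay, and the two values lie within the usual scatter of each other, so they cannot be set in order.

The next compound, compound 3 `CCOC(=O)Cn1cnc2c(Br)ncnc21`, keeps the core of compound 1 and differs from it in one place: bromo in place of chloro on an aromatic carbon. Going by the values given here, no measured pair shows what such a swap does here, so the expectation rests on the swap being small in what it adds. The step from compound 1 to compound 3 is expected to be modest, a 1.3-fold lower number from compound 1 to compound 3 (0.10 log units; within the scatter), and not clearly beyond the scatter in either direction. Compound 3 is therefore estimated at 15000 nM, with a likely range from 6000 nM to 40000 nM.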

Compound 3, half-maximal inhibitory concentration: 13400 nM
Compound 3: the middle estimate sits 1.1-fold (0.05 log units) above what was measured; the measured number falls inside the stated range.
By their numbers in this assay, from the lowest: compounds 3, 2 and 1 (each within the scatter of the next).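

Going by these compounds alone, replacing chloro with bromo on this aromatic carbon gives the first measured step between two compounds that differ in one place (a 1.4-fold lower number from compound 1 to compound 3 (0.15 log units; within the scatter)) in this assay. The step shows that this carbon accepts bromo as well as chloro without a change that can be told from the scatter, something the earlier pair could not show because those two compounds do not form such a step. This is one swap between two halogens, so it says nothing about groups of other kinds, and nothing measured here gives a reason for the result. The compounds shown leave open whether an amine or a methoxy group on this same carbon would move the number beyond the scatter. They also leave open what a carboxylic acid in place of the ester would do.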